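Lengthening the Chloroacyl Chain from Compound 3 to Compound 4

A few compounds are considered here, and "the series" means these few. Any claim that something is new, unique, unknown or untested is made for them only; others in the source may bear on it.

Measured so far in a functional assay on MGC-803 cells (Homo sapiens) for inhibition, read by MTT assay, with a stated time of 48 h; a lower number here means a stronger inhibitor, a higher number a weaker inhibitor:
compound 1, `CCC(=O)N(Cc1ccc(OC)c(O)c1)c1cc(OC)c(OC)c(OC)c1`, gives 50 nM
compound 2, `COc1ccc(CN(C(=O)C2CC2)c2cc(OC)c(OC)c(OC)c2)cc1O`, gives 59 nM
compound 3, `COc1ccc(CN(C(=O)CCl)c2cc(OC)c(OC)c(OC)c2)cc1O`, gives 84 nM

All three share one core and differ only in the group on the carbonyl carbon. Compound 3 has the highest number of the three, yet both steps leading to it are small: a 1.7-fold higher number from compound 1 to compound 3 (0.23 log units; within the scatter) and a 1.4-fold higher number from compound 2 to compound 3 (0.15 log units; within the scatter). The step from cyclopropyl to chloromethyl, a 1.4-fold higher number from compound 2 to compound 3 (0.15 log units; within the scatter), also stays within the scatter.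

Compound 4, `COc1ccc(CN(C(=O)CCCl)c2cc(OC)c(OC)c(OC)c2)cc1O`, is not yet measured. Its change from compound 3 is chloromethyl in place of chloro on a saturated chain carbon bound to a carbonyl carbon. Every change so far at this same position has moved the number only within the scatter, so the expected step is a 1.1-fold lower number from compound 3 to compound 4 (0.05 log units; within the scatter), no change beyond the scatter. The estimate for compound 4 in this assay is 75 nM, within 35 nM to 160 nM.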

Compound 4, half-maximal inhibitory concentration: 140 nM
Compound 4: the middle estimate sits 1.9-fold (0.27 log units) below what was measured, and the stated range covers the measured number.
By their numbers in this assay, from the lowest: compounds 1, 2, 3 and 4 (each within the scatter of the next, the first and the last beyond it).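

Adding one carbon to the chloroacyl chain gives only a small change on its own, with a 1.7-fold higher number from compound 3 to compound 4 (0.22 log units; within the scatter), but this position now shows its first steps beyond the scatter, with a 2.4-fold higher number from compound 2 to compound 4 (0.38 log units; beyond the scatter) and a 2.8-fold higher number from compound 1 to compound 4 (0.45 log units; beyond the scatter). On the carbonyl carbon, 2-chloroethyl therefore gives a weaker inhibitor than cyclopropyl or ethyl, while chloromethyl cannot be separated from any of these three groups. Nothing available here explains this difference.

Still open, on these data alone, is whether a longer chlorinated chain would weaken inhibition further. Also open, as far as these compounds go, is how an amine in place of the chloro would compare.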